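Solubility notes: aromatic ring in place of chain

The compounds below may be only part of what the source reports. "The series", "measured", "known", "first", "only" and "open" are said of these compounds alone.

compound 1 `COc1ccc(F)cc1CNCCCNc1ccnc2cc(Cc3cc(C)cc(C)c3)ccc12`: 4200 nM
compound 2 `c1ccc(-c2ccc3c(NCCCNCc4ccco4)ccnc3c2)cc1`: 32000 nM
compound 3 `CC(C)CCc1ccc2c(NCCCNCc3ccco3)ccnc2c1`: 4200 nM

In a physicochemical assay for solubility, with a stated time of 18 h, at pH 7.4 (on this read-out lower numbers stand for lower solubility and higher numbers for higher solubility), compound 3 gives 4200 nM, level with compound 1 at the digits shown and together with it the lowest of the three numbers; the only step beyond the scatter is a 7.6-fold lower number from compound 2 to compound 3 (0.88 log units; beyond the scatter). Compound 4 `Cc1cc(C)cc(Cc2ccc3c(NCCCNCc4ccco4)ccnc3c2)c1` differs from compound 3 by 3,5-dimethylphenyl in place of isobutyl on a saturated chain carbon bound to an aromatic carbon, at a saturated chain carbon bound to an aromatic carbon. That step bears only partly here: it traded an aromatic ring for a chain, whereas compound 4 brings an aromatic ring back, cut one bond further out. Compound 1 carries the same 3,5-dimethylbenzyl and gives 4200 nM. A step of a 1.1-fold higher number from compound 3 to compound 4 (0.03 log units; within the scatter) is therefore expected, within the scatter. Compound 4 is estimated at 4500 nM, range 1500 nM to 15000 nM.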

Compound 4, solubility: 4200 nM
Estimate against measurement, compound 4: 1.1-fold (0.03 log units) above; the measured number falls inside the stated range.
By their numbers in this assay, from the lowest: compounds 1, 3 and 4 (each within the scatter of the next); then compound 2.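

In this assay, the change on a saturated chain carbon bound to an aromatic carbon gives no change at the digits printed from compound 3 to compound 4 (within the scatter) even though an aromatic ring enters for a chain, so isopentyl and 3,5-dimethylbenzyl read alike here. With 3,5-dimethylbenzyl in place of phenyl on an aromatic carbon the result is a 7.6-fold lower number from compound 2 to compound 4 (0.88 log units; beyond the scatter) and matches the gap seen with isopentyl. Furan-2-yl in place of 5-fluoro-2-methoxyphenyl on a saturated chain carbon bound to an amine nitrogen gives no change at the digits printed from compound 1 to compound 4 (within the scatter) with 3,5-dimethylbenzyl held fixed.

As far as these compounds go, how an amine or a carboxylic acid would read at this position stays open. No measurement in hand accounts for these readings.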